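A Fluorine Swap on a Weakly Active Thiourea

The compounds below may be only part of what the source reports. "The series", "measured", "known", "first", "only" and "open" are said of these compounds alone.

compound 1, `NC(=O)c1c(NC(=O)c2ccccc2F)sc2c1CCN(Cc1cccc(Cl)c1)C2`: 49500 nM
compound 2, `NC(=O)c1c(NC(=O)c2ccccc2)sc2c1CCN(C(=S)Nc1ccccc1Cl)C2`: > 50000 nM

Of the compounds shown here, two have been tested in a functional assay on HeLa cells (Homo sapiens) for antiproliferative activity, with a stated time of 24 h; on this read-out higher numbers stand for weaker inhibition and lower numbers for stronger inhibition. Compound 1 gives 49500 nM, a weak effect. For compound 2 the result is only a limit of the assay, > 50000 nM, so its true strength is not known. Compound 2 thus stands at the limit of > 50000 nM in this assay, at which 1 of the 2 values shown sits.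

Compound 3, `NC(=O)c1c(NC(=O)c2ccccc2F)sc2c1CCN(C(=S)Nc1ccccc1Cl)C2`, has not yet been measured. It differs from compound 2 in one place: fluoro in place of hydrogen on an aromatic carbon. Compound 1 carries the same fluoro group on the same ring and still gives only 49500 nM, so this change alone gives no ground to expect a strong gain. The step from compound 2 to compound 3 in this assay is expected to be a number no higher from compound 2 to compound 3 (the limit leaves the size open), with no direction beyond the scatter. Compound 3 is therefore estimated at 50000 nM, between 25000 nM and 100000 nM, and the measurement may again come back only as a limit.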

Compound 3, half-maximal inhibitory concentration: 19400 nM
Estimate against measurement, compound 3: 2.6-fold (0.41 log units) above; measured number below the stated range.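

In this assay, putting fluoro on this aromatic carbon, a change of a single atom, gives an at least 2.5-fold lower number from compound 2 to compound 3 (0.41 log units; beyond the scatter), so this position does respond to substitution. With the fluoro group kept in place, exchanging the group on the amine nitrogen in the ring gives a 2.6-fold lower number from compound 1 to compound 3 (0.41 log units; beyond the scatter), which shows that the two sites can both be changed with a measurable result. Compound 2 stands only at a limit of the assay, so the full size of the fluoro step stays unknown: the limit of > 50000 nM in this assay, at which 1 of the 3 values shown sits.

The compounds shown carry only hydrogen or fluoro at this place, so it remains open whether a methoxy group, a methyl group or a chlorine atom there would do the same, or more. Compound 3, at 19400 nM, is still a weak inhibitor, and what lies behind its gain cannot be read from these values.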